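The compounds below may be only part of what the source reports. "The series", "measured", "known", "first", "only" and "open" are said of these compounds alone.

Measured compounds in an ADME assay on cells (Hepatocyte, Mus musculus) for metabolic stability, with a stated time of 30 min; a higher number here means that more of the compound is left, a lower number that less of the compound is left:

Compound 1 `O=C(OC1CCC(CN2CCN(c3cc(=O)c4cc(C(F)(F)F)cc([N+](=O)[O-])c4s3)CC2)CC1)c1ccco1`: 0.6%
Compound 2 `CS(=O)(=O)NC1CCC(CN2CCN(c3cc(=O)c4cc(C(F)(F)F)cc([N+](=O)[O-])c4s3)CC2)CC1`: 111%
Compound 3 `O=c1cc(N2CCN(CC3CCC(O)CC3)CC2)sc2c([N+](=O)[O-])cc(C(F)(F)F)cc12`: 51.2%

Compound 3 holds the middle position of the three in this assay: it sits above compound 1 and below compound 2, both gaps beyond the scatter. The two steps ending in it are a number 50.6 percentage points higher from compound 1 to compound 3 (beyond the scatter) and a number 59.8 percentage points lower from compound 2 to compound 3 (beyond the scatter).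

The next compound, compound 4 `O=C(OC1CCC(CN2CCN(c3cc(=O)c4cc(C(F)(F)F)cc([N+](=O)[O-])c4s3)CC2)CC1)c1cccs1`, has not yet been run in this assay. Compared with compound 3 the change is (thiophen-2-yl)carbonyl in place of hydrogen on an oxygen on a saturated carbon.

The step that bears on this most directly is a number 50.6 percentage points higher from compound 1 to compound 3 (beyond the scatter), where removing a (furan-2-yl)carbonyl from the same oxygen on a saturated carbon raised the remaining fraction by a large margin; compound 4 puts back an ester of the same kind, with (thiophen-2-yl)carbonyl instead of (furan-2-yl)carbonyl. The step of a number 59.8 percentage points lower from compound 2 to compound 3 (beyond the scatter) also shows that the group on this saturated ring carbon moves the read-out strongly. Compound 4 is therefore expected to drop sharply in this assay, an estimated step of a number 48.2 percentage points lower from compound 3 to compound 4 (beyond the scatter). The value for compound 4 is estimated at 3%, with a range from 0% to 20%.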

Compound 4, percent of the compound remaining: 1.8%
Compound 4: the middle estimate sits 1.2 percentage points above what was measured; measured number inside the range.
By their numbers in this assay, from the lowest: compounds 1 and 4 (each within the scatter of the next); then compound 3; then compound 2.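

In this assay, putting (thiophen-2-yl)carbonyl on the oxygen on a saturated carbon gives a number 49.4 percentage points lower from compound 3 to compound 4 (beyond the scatter), so the large fall seen with the (furan-2-yl)carbonyl ester at this oxygen now appears with a second acyl group. Exchanging the ring on the carbonyl carbon gives a number 1.2 percentage points higher from compound 1 to compound 4 (within the scatter), which lies within the scatter, so this pair does not separate thiophen-2-yl from furan-2-yl, and both esters sit at the low end of the read-out. The comparison with the sulfonamide, a number 109.2 percentage points lower from compound 2 to compound 4 (beyond the scatter), adds a second large step at the same saturated ring carbon, and in all the compounds shown the group at this carbon moves the read-out strongly, with both esters far below the hydroxy and methanesulfonamido compounds.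

Nothing measured here explains why the two esters leave so little compound. Still open, from the compounds shown here alone, is whether the low numbers go with the ester link or with the aromatic ring on the carbonyl, a question that an acetyl ester on the same oxygen or a furan-2-carboxamide on the same saturated ring carbon would address.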